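Antiproliferative series: a chloro addition to compound 1

A few compounds are considered here, and "the series" means these few. Any claim that something is new, unique, unknown or untested is made for them only; others in the source may bear on it.

Measured compounds:
compound 1 `OC[C@H]1O[C@@H](n2cnc3c(NCc4ccc(F)cc4)ncnc32)[C@H](O)[C@@H]1O` — 1200 nM
compound 2 `OC[C@H]1O[C@@H](n2cnc3c(NCc4cccc(Br)c4)ncnc32)[C@H](O)[C@@H]1O` — 8000 nM
compound 3 `COc1cccc(CNc2ncnc3c2ncn3[C@@H]2O[C@H](CO)[C@@H](O)[C@H]2O)c1` — 4900 nM

In a functional assay on HL-60 cells (Homo sapiens) for antiproliferative activity, with a stated time of 72 h (on this read-out lower numbers stand for stronger inhibition and higher numbers for weaker inhibition), compound 1 gives the lowest number of the three; its steps to the others are both beyond the scatter, a 4.1-fold higher number from compound 1 to compound 3 (0.61 log units; beyond the scatter) and a 6.7-fold higher number from compound 1 to compound 2 (0.82 log units; beyond the scatter), so compound 1 is the most potent compound measured here. Compound 4 `OC[C@H]1O[C@@H](n2cnc3c(NCc4ccc(F)cc4Cl)ncnc32)[C@H](O)[C@@H]1O` differs from compound 1 by chloro in place of hydrogen on an aromatic carbon. Within the data shown here, no measured step adds a group while keeping the fluoro group; the two steps away from compound 1 exchange the whole ring pattern and both weaken, while a 1.6-fold lower number from compound 2 to compound 3 (0.21 log units; within the scatter) shows that swapping one ring substituent for another can leave the number unchanged. A small to modest weakening is therefore expected for compound 4, a 1.7-fold higher number from compound 1 to compound 4 (0.22 log units; within the scatter). Compound 4 is estimated at 2000 nM, between 700 nM and 6000 nM.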

Compound 4, half-maximal inhibitory concentration: 9000 nM
Beside the measured number, compound 4's estimate is 4.5-fold (0.65 log units) below it; measured number outside the range, above it.
By their numbers in this assay, from the lowest: compound 1; then compounds 3, 2 and 4 (each within the scatter of the next).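

In this assay, chloro in place of hydrogen ortho to a large group and meta to the fluoro group weakens compound 1 with the fluoro group kept: a 7.5-fold higher number from compound 1 to compound 4 (0.88 log units; beyond the scatter). The 2-chloro-4-fluorophenyl group cannot be told apart from the other two ring patterns, with a 1.8-fold higher number from compound 3 to compound 4 (0.26 log units; within the scatter) and a 1.1-fold higher number from compound 2 to compound 4 (0.05 log units; within the scatter). Nothing shown here accounts for this weakening. Open, as far as these compounds go, is whether it belongs to chloro itself or to this place on the ring. A methyl or methoxy group at the same place would separate the two.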